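The source may report more compounds than this note shows. Statements on the series, on what has been measured and on what is new or still open speak of the compounds shown alone.

Working notes on the series. In a functional assay on DU-145 cells (Homo sapiens) for cytotoxicity, read by trypan blue exclusion, with a stated time of 96 h (a lower number here means a stronger inhibitor, a higher number a weaker inhibitor), compound 1 `COc1ccccc1/C=C/S(=O)(=O)Cc1ccc(OC)c([N+](=O)[O-])c1` gives 20000 nM, compound 2 `COC(=O)CNc1cc(CS(=O)(=O)/C=C/c2c(OC)cc(OC)cc2OC)ccc1OC` gives 100 nM, and compound 3 `COC(=O)C(Nc1cc(CS(=O)(=O)/C=C/c2c(OC)cc(OC)cc2OC)ccc1OC)c1ccc(OC)cc1` gives 250 nM. Compound 2 stands lowest of the three numbers; compound 3 is the nearest to it and compound 1 the furthest. Compound 4 `COc1cc(OC)c(/C=C/S(=O)(=O)Cc2ccc(OC)c(N[C@@H](C)C(=O)O)c2)c(OC)c1` differs from compound 2 as follows: 1-carboxyethyl in place of (methoxycarbonyl)methyl on a nitrogen on an aromatic ring. Among the measured compounds shown here, the only single-point step measured, a 2.5-fold higher number from compound 2 to compound 3 (0.40 log units; beyond the scatter), concerns a different position and does not touch the change at hand, so nothing measured bears directly on it. The expectation is therefore a step near or within the scatter, leaning slightly upward, giving an estimated 2.0-fold higher number from compound 2 to compound 4 (0.30 log units; within the scatter). Compound 4 is expected to give about 200 nM, within a range from 60 nM to 700 nM.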

Compound 4, half-maximal inhibitory concentration: 25 nM
For compound 4 the middle estimate is 8.0-fold (0.90 log units) above the measured one; measured number outside the range, below it.
By their numbers in this assay, from the lowest: compound 4; then compound 2; then compound 3; then compound 1.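

In this assay there is a 4.0-fold lower number from compound 2 to compound 4 (0.60 log units; beyond the scatter) with 1-carboxyethyl in place of (methoxycarbonyl)methyl on a nitrogen on an aromatic ring, so the number responds to the substituent at this position. The change adds a hydrogen-bond donor and a defined stereocentre in a single step, and the two cannot be separated here. Nothing available explains the direction of this step. Open, on these data alone, is how a carboxymethyl group, the methyl ester of 1-carboxyethyl or the opposite stereocentre would read at this nitrogen.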